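The source may report more compounds than this note shows. Statements on the series, on what has been measured and on what is new or still open speak of the compounds shown alone.

Among the compounds with values here, in an assay on blood for inhibition of C-X-C chemokine receptor type 3 (Homo sapiens), with a stated time of 30 min (on this read-out higher numbers stand for weaker inhibition and lower numbers for stronger inhibition), compound 3 `CCOc1ncc(-c2nc(C(F)(F)F)sc2N2CCN(C(=O)Cn3nc(C)nc3C)[C@H](C)C2)cn1` gives 364 nM, the highest of the three numbers known; compound 1 `COc1ncc(-c2nc(C(F)(F)F)sc2N2CCN(C(=O)Cn3cnc4cccnc43)[C@H](C)C2)cn1` gives 158 nM and compound 2 `CCOc1ncc(-c2nc(C(F)(F)F)sc2N2CCN(C(=O)Cn3nc(C)cc3C)[C@H](C)C2)cn1` gives 60 nM. Within the data shown here, the only single-site step among them, a 6.1-fold higher number from compound 2 to compound 3 (0.78 log units; beyond the scatter), concerns the ring on the saturated chain carbon bound to the carbonyl carbon and not the ethoxy group. Compound 4 `COc1ncc(-c2nc(C(F)(F)F)sc2N2CCN(C(=O)Cn3nc(C)nc3C)[C@H](C)C2)cn1` differs from compound 3 by hydrogen in place of methyl on a saturated chain carbon bound to an oxygen on an aromatic ring. Among the measured compounds shown here, no measured step touches the ethoxy group alone; compound 1 and compound 2 differ both there and at the ring, so their values give no separate reading. The step is therefore expected to be a 1.0-fold lower number from compound 3 to compound 4 (0.00 log units; within the scatter). Compound 4 is estimated at 360 nM, between 150 nM and 850 nM.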

Compound 4, half-maximal inhibitory concentration: 1040 nM
Compound 4: the middle estimate sits 2.9-fold (0.46 log units) below what was measured; the measured number lies above the stated range.
By their numbers in this assay, from the lowest: compound 2; then compound 1; then compound 3; then compound 4.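

The ethoxy group is not a silent place: with the ring on the chain carbon held fixed, ethoxy to methoxy alone gives a 2.9-fold higher number from compound 3 to compound 4 (0.46 log units; beyond the scatter) in this assay. With methoxy held fixed, a group with one five-membered aromatic ring in place of one with a five-membered and a six-membered aromatic ring gives a 6.6-fold higher number from compound 1 to compound 4 (0.82 log units; beyond the scatter). Nothing available explains either step. As far as these compounds go, whether the ethoxy-to-methoxy step holds with the 3,5-dimethyl-1H-pyrazol-1-yl group stays open, as does how a longer chain such as propoxy would read at this place.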